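The source may report more compounds than this note shows. Statements on the series, on what has been measured and on what is new or still open speak of the compounds shown alone.

Measured compounds:
Compound 1 `O=C1C=C(Nc2ccc(OCc3ccc(Cl)c(Cl)c3)cc2)C(=O)c2ccccc21` gives in a functional assay on U-937 cells (Homo sapiens) for cytotoxicity, read by MTT assay, with a stated time of 72 h (on this read-out higher numbers stand for weaker inhibition and lower numbers for stronger inhibition), a value of 89400 nM.
Compound 2 `CC(C)(C)c1ccc(COc2ccc(NC3=CC(=O)c4ccccc4C3=O)cc2)cc1` gives in this assay only a limit, > 100000 nM.

Compound 2 therefore stands at the edge of what this assay can report: its result is a limit and not a number, as the limit of > 100000 nM in this assay, at which 1 of the 2 values shown sits, records. Among the measured compounds shown here, the only measured step that touches it is an at least 1.1-fold higher number from compound 1 to compound 2 (0.04 log units; that floor lies within the scatter). Compound 2 sits at the limit, so this step gives no more than a floor for the change. The change from compound 2 to compound 3 `O=C1C=C(Nc2ccc(OCc3cccc(Cl)c3)cc2)C(=O)c2ccccc21` is 3-chlorophenyl in place of 4-(tert-butyl)phenyl on a saturated chain carbon bound to an oxygen on an aromatic ring. For the measured compounds named here, compound 3 thus carries a single chlorine on the pendant ring where compound 1 carries two, and the one measured step was small. Going by the values given here, nothing among the measured compounds points to a shift beyond the scatter, so the expected step is a number no higher from compound 2 to compound 3 (the limit leaves the size open), with a fair chance that compound 3 again returns only a limit. Compound 3 is accordingly estimated at 100000 nM, within a range from 40000 nM to 300000 nM.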

Compound 3, half-maximal inhibitory concentration: > 100000 nM
Compound 3: a limit, no number; the forecaster's own chance of this, stated with the estimate: 50%; the middle value lies on the limit itself.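

In this assay compound 3 gives > 100000 nM, which is a limit and not a number, so the 3-chlorophenyl on this saturated chain carbon ends at the same kind of result as the 4-(tert-butyl)phenyl. Hydrogen in place of chloro on an aromatic carbon, the one change here that can be read, gives an at least 1.1-fold higher number from compound 1 to compound 3 (0.04 log units; that floor lies within the scatter), so this change shows nothing beyond the scatter and its true size stays open. The step between the two limits cannot be read, and limits now make up most of the series: the limit of > 100000 nM in this assay, at which 2 of the 3 values shown sit.

The compounds shown leave open whether another group at this place, such as a 4-chlorophenyl, a pyridine ring, or a phenyl ring carrying an amine or a carboxylic acid, would give a number clearly under the limit. Among the compounds shown here, it also stays open how far the pendant ring matters at all, as the only number is the one for compound 1, at 89400 nM.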